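The source may hold more compounds than are shown below. What is called first, only, known or untested is meant among the compounds shown, and "the series" means these compounds.

In a functional assay on DU-145 cells (Homo sapiens) for cytotoxicity, read by CCK-8 assay and cell counting, with a stated time of 72 h (on this read-out higher numbers stand for weaker inhibition and lower numbers for stronger inhibition), compound 1 `COc1ccc(-c2cc3ccccc3c(-c3cccc(O)c3)n2)cc1` gives 5360 nM. Compound 2 `COc1ccc(-c2cc3ccccc3c(-c3cccc(N)c3)n2)cc1` gives 8610 nM, and the step is a 1.6-fold higher number from compound 1 to compound 2 (0.21 log units; within the scatter). Compound 3 `COc1ccc(-c2cc3ccccc3c(-c3ccc(O)cc3)n2)cc1` returns only a limit, > 50000 nM.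

Compound 4 `COc1ccc(-c2cc3ccccc3c(-c3ccc(OC)cc3)n2)cc1` carries 4-methoxyphenyl in place of 3-hydroxyphenyl, next to the ring nitrogen: 4-methoxyphenyl in place of 3-hydroxyphenyl on an aromatic carbon. The nearest precedents are the two steps ending at the 4-hydroxyphenyl of compound 3, an at least 9.3-fold higher number from compound 1 to compound 3 (0.96 log units; beyond the scatter) and an at least 5.8-fold higher number from compound 2 to compound 3 (0.76 log units; beyond the scatter). Both are lower bounds, so a clear rise is expected in this assay, and it may reach the limit.

The expected change is a 6.5-fold higher number from compound 1 to compound 4 (0.81 log units; beyond the scatter).

Compound 4 is estimated at 35000 nM, with an expected range of 12000 nM to 100000 nM.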

Compound 4, half-maximal inhibitory concentration: > 50000 nM
Compound 4: no number, only a limit; the forecaster's own chance of this, stated with the estimate: 55%; middle value at least 1.4-fold (0.15 log units) from the limit.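

With 4-methoxyphenyl in place of 3-hydroxyphenyl the result is an at least 9.3-fold higher number from compound 1 to compound 4 (0.96 log units; beyond the scatter), and in place of 3-aminophenyl it is an at least 5.8-fold higher number from compound 2 to compound 4 (0.76 log units; beyond the scatter). The 4-hydroxyphenyl of compound 3 carries a hydrogen-bond donor and the 4-methoxyphenyl of compound 4 carries none, yet both compounds end at a limit rather than a number. The step between them therefore cannot be read: the limit of > 50000 nM in this assay, at which 2 of the 4 values shown sit.

A 3-methoxyphenyl group would show whether the loss follows the position of the substituent or the methyl on the oxygen. On these data alone, how a 4-aminophenyl group behaves also remains open.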